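Fluoro for Hydrogen on a Core That Shows No Potency

The compounds below may be only part of what the source reports. "The series", "measured", "known", "first", "only" and "open" are said of these compounds alone.

Compound 3 `C=C1C[C@]23C[C@@]1(O)CC[C@H]2c1ccc(O)c(C)c1[C@@H]3Cn1cc(-c2ccccc2)nn1` carries an unsubstituted phenyl ring on the triazole of the shared core. In a functional assay on HL-60 cells (Homo sapiens) for cytotoxicity, read by MTT assay, with a stated time of 4 days (on this read-out higher numbers stand for weaker inhibition and lower numbers for stronger inhibition), compound 3 gives only a limit, > 20000 nM, not a measured number. Compound 1 `C=C1C[C@]23C[C@@]1(O)CC[C@H]2c1ccc(O)c(C)c1[C@@H]3Cn1cc(-c2ccc(Br)cc2)nn1` is the bromo-bearing counterpart of compound 3 on that phenyl ring. In this assay compound 1 also stops at a limit, > 20000 nM. Compound 2 `C=C1C[C@]23C[C@@]1(O)CC[C@H]2c1ccc(OS(=O)(=O)c2ccc(C)cc2)c(C)c1[C@@H]3Cn1cc(-c2ccc(F)cc2)nn1` is altered elsewhere in the core and carries a fluoro on the same ring. In this assay compound 2 likewise reaches only a limit, > 20000 nM. Compound 3 thus stands exactly where every measured compound stands, because the limit of > 20000 nM in this assay, at which 3 of the 3 values shown sit, covers all of them. The step that the two limits leave unreadable from compound 1 to compound 3 cannot be read in size, since both of its ends are limits.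

Compound 4 `C=C1C[C@]23C[C@@]1(O)CC[C@H]2c1ccc(O)c(C)c1[C@@H]3Cn1cc(-c2ccc(F)cc2)nn1` differs from compound 3 by fluoro in place of hydrogen on an aromatic carbon. Going by the values given here, the only measured step touching the same aromatic carbon, from compound 1 to compound 3, is unreadable, so no measured step gives grounds to expect a gain in this assay. The expected step is therefore a step that the limit leaves unreadable from compound 3 to compound 4, which amounts to no change beyond scatter. Compound 4 is expected to give about 25000 nM, with a range from 10000 nM to 60000 nM, most probably reported again as a limit.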

Compound 4, half-maximal inhibitory concentration: > 20000 nM
Compound 4 ended at the assay's limit; the forecaster's own chance of this, stated with the estimate: 85%; the middle value does not contradict the limit.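

The steps joining compound 4 to compound 1, compound 2 and compound 3 in this assay cannot be read in size, because each of these compounds gives only a limit, not a number: the limit of > 20000 nM in this assay, at which 4 of the 4 values shown sit. The compounds shown leave open whether any change to the shared core gives a measurable value in this assay at all, and what fluoro in place of hydrogen does to potency.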